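Adding a Hydroxy Group to an Inactive Silyl Ether

The compounds below may be only part of what the source reports. "The series", "measured", "known", "first", "only" and "open" are said of these compounds alone.

Measured in an ADME assay on ECV-304 cells (Homo sapiens) for cytotoxicity, read by MTT assay, with a stated time of 72 h; a higher number here means a weaker inhibitor, a lower number a stronger inhibitor:
- Compound 1 `COc1ccc(C2=C(c3cc(OC)c(OC)c(OC)c3)C(=O)CC2O[SiH2]C(C)(C)C)cc1`: > 100 ug/mL (a limit)
- Compound 2 `COc1ccc(C2=C(c3cc(OC)c(OC)c(OC)c3)C(=O)C(OC(C)=O)C2)cc1Cl`: 3.5 ug/mL
- Compound 3 `CC(=O)OC1C/C(=N/O)C(c2ccccc2)=C1c1ccccc1`: > 100 ug/mL (a limit)

Compound 1 has no exact number, only a limit of > 100 ug/mL. It stands with the least informative results in this small set: the limit of > 100 ug/mL in this assay, at which 2 of the 3 values shown sit. Going by the values given here, compound 2 is the only one with an exact reading, at 3.5 ug/mL.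

Compound 4 `COc1ccc(C2=C(c3cc(OC)c(OC)c(OC)c3)C(=O)CC2O[SiH2]C(C)(C)C)cc1O` differs from compound 1 in one place: hydroxy in place of hydrogen on an aromatic carbon. The 4-methoxyphenyl becomes 3-hydroxy-4-methoxyphenyl, with hydroxy in place of hydrogen on an aromatic carbon. Among the compounds with values here, no measured pair here shows what such a change does, so any forecast is uncertain, and another limit remains possible. Compound 2 at 3.5 ug/mL shows that a number can be reached in this set, so a move toward stronger inhibition seems more likely than none. The expected change is an at least 5.0-fold lower number from compound 1 to compound 4 (0.69 log units; beyond the scatter), and this is only an estimate. For compound 4 the estimated value is 20 ug/mL, with an expected range of 2 ug/mL to 100 ug/mL.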

Compound 4, half-maximal inhibitory concentration: 30 ug/mL
Beside the measured number, compound 4's estimate is 1.5-fold (0.18 log units) below it; the range from low to high includes it.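

In this assay, putting hydroxy in place of hydrogen on the 4-methoxyphenyl gives an at least 3.3-fold lower number from compound 1 to compound 4 (0.52 log units; beyond the scatter), so this single change at a position ortho to a methoxy group is enough to yield an exact reading. Going by these compounds alone, this is the first pair in the set that differs in one place, which makes it the first direct view of what any one change does here. Compound 1 has only a limit, so the step gives a minimum and not a full size, and such limits are common in this small set: the limit of > 100 ug/mL in this assay, at which 2 of the 4 values shown sit.

The compounds shown leave open whether hydroxy is special at this position, or whether an amine or a fluorine atom placed there would give a similar result. They also leave open whether the hydroxy would have the same effect with a carboxylic acid in place of the silyl ether.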